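Testing a Bromophenyl Analogue for Growth Inhibition

This account rests on a few compounds, and the source may have more. Where it says the series, first, only, none or still open, it means among the compounds named here.

Compound 1 `O=C(/C=C\c1cccc([N+](=O)[O-])c1)N1N=C(c2ccncc2)OC1c1c[nH]c2ccccc12` was examined in an ADME assay on HeLa cells (Homo sapiens) for cytotoxicity, read by MTT assay, with a stated time of 72 h; a lower number here means a stronger inhibitor of growth, a higher number a weaker inhibitor of growth. In this assay compound 1 gives > 30 ug/mL, and that figure is a limit of the assay rather than a measured number. Among the compounds with values here, compound 2 `O=C(/C=C\c1ccccc1Cl)N1N=C(c2ccncc2)OC1c1c[nH]c2ccccc12` is the only other compound measured here. In this assay compound 2 gives > 30 ug/mL, again a limit and not a number. Within the data shown here, the one measured step, a step that the two limits leave unreadable from compound 1 to compound 2, therefore cannot be sized, since both compounds sit at the limit of > 30 ug/mL in this assay, at which 2 of the 2 values shown sit, and neither value says how far each compound lies past that point.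

Compound 3 `O=C(/C=C\c1ccc(Br)cc1)N1N=C(c2ccncc2)OC1c1c[nH]c2ccccc12` has not yet been measured in this assay. Its difference from compound 1 is 4-bromophenyl in place of 3-nitrophenyl on a double-bonded chain carbon bound to a double-bonded chain carbon. Among the measured compounds shown here, the only measured step bears on a change at the same place, a switch of one substituted phenyl for another, and it gave no readable size. The expectation is that compound 3 stays weak in this assay and most likely also returns only a limit. Compound 3 is expected to give about 45 ug/mL, with a range from 20 ug/mL to 100 ug/mL. The step that the limit leaves unreadable from compound 1 to compound 3 is expected to stay within the scatter.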

Compound 3, concentration for 50% growth inhibition: > 30 ug/mL
Compound 3: no number, only a limit (the forecaster's own chance of this, stated with the estimate: 75%); the middle value lies beyond the limit too.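

In this assay compound 3 gives > 30 ug/mL, which is a limit and not a number. The steps among compound 1, compound 2 and compound 3 therefore cannot be read, as all three stop at the same point: the limit of > 30 ug/mL in this assay, at which 3 of the 3 values shown sit.

The compounds shown leave open how far past that limit each one lies, and whether any other substituted phenyl group would give a measurable value.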